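The source may hold more compounds than are shown below. What is called first, only, known or untested is meant among the compounds shown, and "the series" means these compounds.

Going by the values given here, only two compounds have been measured so far in an ADME assay on microsomes from liver (Mus musculus) for metabolic stability, read by LC-MS, with a stated time of 30 min, tested at 1 uM; on this read-out lower numbers stand for a less stable compound and higher numbers for a more stable compound. Compound 1 (`Cn1c(C(=O)NCc2ccc(S(=O)(=O)c3ccccc3)cc2)cc2cnccc21`) gives 34% and compound 2 (`O=C(NCc1ccc(S(=O)(=O)c2ccccc2)cc1)c1ccc2nncn2c1`) gives 47%. Compound 2 therefore holds the higher of the two numbers, and the gap between them lies beyond the usual scatter.

Compound 3 (`O=C(NCc1ccc(S(=O)(=O)c2ccccc2)cc1)c1cc2cnccc2[nH]1`) differs from compound 2 in one place, on a carbonyl carbon: a group of 9 heavy atoms (7 carbon, 2 nitrogen; one five-membered aromatic ring with 1 hetero atom, one six-membered aromatic ring with 1 hetero atom) in place of a group of 9 heavy atoms (6 carbon, 3 nitrogen; one five-membered aromatic ring with 3 hetero atoms, one six-membered aromatic ring with 1 hetero atom), on a carbonyl carbon. Both groups hold a five-membered aromatic ring and a six-membered aromatic ring, so the difference lies in the atoms those rings carry.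

Among the compounds with values here, no two measured compounds differ in just one place, which leaves no measured step to use as a guide. Within the data shown here, the only hint is that compound 1, at 34%, stands lower than compound 2, so a fall seems likelier than a rise, though this rests on very little. The expected change is modest, a number 9 percentage points lower from compound 2 to compound 3 (within the scatter), and may stay within the usual scatter. In this assay, the estimate for compound 3 is 38%, with an expected range from 18% to 60%.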

Compound 3, percent of the compound remaining: 54%
Compound 3: the middle estimate sits 16 percentage points below what was measured, within the range that was stated.
By their numbers in this assay, from the lowest: compound 1; then compounds 2 and 3 (each within the scatter of the next).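

In this assay, a five-membered aromatic ring with 1 hetero atom in place of one with 3 hetero atoms, on the carbonyl carbon, gives a number 7 percentage points higher from compound 2 to compound 3 (within the scatter), so this position tolerates that change of ring atoms without a shift that can be told from the scatter. Going by these compounds alone, the new compound also opens a second comparison, since hydrogen in place of methyl on an aromatic nitrogen gives a number 20 percentage points higher from compound 1 to compound 3 (beyond the scatter), and this is the only step so far that lies beyond the scatter, showing that a single methyl on that nitrogen goes with a real difference in the percentage of compound remaining. No measurement offers an explanation for either step.

On these data alone, it remains open whether an ethyl group or a longer chain on that aromatic nitrogen would give a number closer to that of compound 1 or to that of compound 3. Also unsettled is how far the tolerance on the carbonyl carbon extends, for example to a ring group carrying an amine or a carboxylic acid.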